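A few compounds are considered here, and "the series" means these few. Any claim that something is new, unique, unknown or untested is made for them only; others in the source may bear on it.

Measured in a functional assay on A-375 cells (Homo sapiens) for antiproliferative activity, read by MTT assay, with a stated time of 72 h; on this read-out lower numbers stand for stronger inhibition and higher numbers for weaker inhibition:

Compound 1 `COc1ncc(-c2ccc3c(c2)N(c2ccccc2)C(=O)CO3)cc1NS(=O)(=O)c1ccc(F)cc1`: 15200 nM
Compound 2 `O=C1COc2ccc(-c3cnc(Cl)c(NS(=O)(=O)c4ccc(F)cc4)c3)cc2N1`: > 40000 nM (a limit)
Compound 3 `CC(C)N1C(=O)COc2ccc(-c3cccc(NS(=O)(=O)c4ccc(F)cc4)c3)cc21`: > 40000 nM (a limit)

Compound 3 stands at the limit of > 40000 nM in this assay, at which 2 of the 3 values shown sit, so its reading is a limit and not a number. Compound 2 shares that same limit. Only compound 1 returns a number in this assay, at 15200 nM.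

The next compound, compound 4 `COc1ccc(N2C(=O)COc3ccc(-c4cccc(NS(=O)(=O)c5ccc(F)cc5)c4)cc32)cc1`, is compound 3 with 4-methoxyphenyl in place of isopropyl on an amide-type nitrogen in a ring. Among the measured compounds shown here, no measured pair isolates this change, so the expectation rests on thin ground. Compound 1 also carries an aromatic ring on that nitrogen and gives 15200 nM, although it differs from compound 4 elsewhere as well. On that single comparison, a modest step towards stronger inhibition is expected in this assay, and compound 4 may well remain at the limit instead. The estimated change is an at least 1.6-fold lower number from compound 3 to compound 4 (0.20 log units; that floor lies within the scatter). For compound 4 the expected value is 25000 nM, with an estimated range from 8000 nM to 60000 nM.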

Compound 4, half-maximal inhibitory concentration: 38500 nM
The estimate for compound 4 lay 1.5-fold (0.19 log units) below the measured number, within the range that was stated.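

In this assay, compound 4 returns a number where compound 3 returned only a limit, so this place on the amide-type nitrogen in a ring can carry 4-methoxyphenyl and still give a measurable reading. The change reads as an at least 1.0-fold lower number from compound 3 to compound 4 (0.01 log units; that floor lies within the scatter), which gives a floor for the step and not its size, so the result does not establish that 4-methoxyphenyl outperforms isopropyl here. The reading for compound 3 remains a limit and not a number, and that limit bounds the whole comparison: the limit of > 40000 nM in this assay, at which 2 of the 4 values shown sit.

The compounds shown leave open how far compound 3 truly lies from compound 4, and whether the outcome depends on the methoxy group or on the aromatic ring that enters with it. They also leave open how this nitrogen would behave in the same setting with a chain ending in an amine or a carboxylic acid, groups that do not appear at this place in any compound shown.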